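Chloro in place of fluoro: compound 2 to compound 3

The source may report more compounds than this note shows. Statements on the series, on what has been measured and on what is new or still open speak of the compounds shown alone.

In a functional assay on DU-145 cells (Homo sapiens) for cytotoxicity, read by trypan blue exclusion, with a stated time of 96 h (on this read-out higher numbers stand for weaker inhibition and lower numbers for stronger inhibition), compound 1 `COc1cc(OC)c(/C=C/S(=O)(=O)Nc2ccc(OC)c(NC(C)C(=O)O)c2)c(OC)c1` gives 40 nM and compound 2 `COc1cc(OC)c(/C=C/S(=O)(=O)Nc2ccc(OC)c(NC(C(=O)O)c3ccc(F)cc3)c2)c(OC)c1` gives 75 nM. Within the data shown here, these two values lie within the scatter of each other, so the numbers so far do not separate compound 2 from the only other measured member of the series.

Compound 3 `COc1cc(OC)c(/C=C/S(=O)(=O)Nc2ccc(OC)c(NC(C(=O)O)c3ccc(Cl)cc3)c2)c(OC)c1` carries chloro in place of fluoro on an aromatic carbon, para to a large group: chloro in place of fluoro on an aromatic carbon.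

Among the measured compounds shown here, one measured step bears on this change, the replacement of methyl by 4-fluorophenyl on a saturated chain carbon: a 1.9-fold higher number from compound 1 to compound 2 (0.27 log units; within the scatter). That step exchanges a whole group and still stays within the scatter. For the measured compounds named here, it touches the same side chain, but no measured step exchanges one halogen for another, so the evidence is indirect and thin. On that basis, no shift beyond the scatter is expected in this assay, and no direction can be assigned with confidence.

The expected change is a 1.1-fold lower number from compound 2 to compound 3 (0.03 log units; within the scatter). Compound 3 is estimated at 70 nM, with an expected range of 30 nM to 170 nM.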

Compound 3, half-maximal inhibitory concentration: 75 nM
Beside the measured number, compound 3's estimate is 1.1-fold (0.03 log units) below it, within the range that was stated.
By their numbers in this assay, from the lowest: compounds 1, 2 and 3 (each within the scatter of the next).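

In this assay, among these compounds, the exchange of one halogen for the other on this aromatic carbon, para to a large group, reads no change at the digits printed from compound 2 to compound 3 (within the scatter) and so gives the first direct look at this change: 4-fluorophenyl and 4-chlorophenyl are not separated on this read-out. The second aryl group on the saturated chain carbon reads a 1.9-fold higher number from compound 1 to compound 3 (0.27 log units; within the scatter) against methyl, so two different halophenyl groups now stand within the scatter of methyl at this carbon, where previously only one did. No measured property is available to account for this reading.

The compounds shown leave open whether a group of another kind on this aromatic carbon, such as a nitrile, an amine or a trifluoromethyl, would read any differently from the two halogens. Also open, from the compounds shown here alone, is whether the saturated chain carbon tolerates groups other than methyl and the two halophenyl groups, for example a longer chain or a benzyl, without a shift beyond the scatter in this assay.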